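The source may report more compounds than this note shows. Statements on the series, on what has been measured and on what is new or still open speak of the compounds shown alone.

Working notes on the series. The shared core carries an amino group and a variable substituent on the five-membered ring; compound 1 `CCOC(=O)c1sc2nc(-c3cccs3)cc(-c3ccccc3)c2c1N` bears an ethoxycarbonyl there. In an assay for inhibition of 15-hydroxyprostaglandin dehydrogenase [NAD(+)] (Homo sapiens), read by fluorescence, with a stated time of 15 min, in the presence of a further agent that is not named here (on this read-out lower numbers stand for stronger inhibition and higher numbers for weaker inhibition), compound 1 returns only a limit, > 7500 nM, not a number. Compound 2 `CCCCSc1sc2nc(-c3cccs3)cc(-c3ccccc3)c2c1N` carries butylsulfanyl in its place. In this assay compound 2 likewise returns only a limit, > 80 nM. The step that the two limits leave unreadable from compound 1 to compound 2 cannot be sized, since both ends sit at limits (the limit of > 7500 nM in this assay, at which 1 of the 2 values shown sits, and (the limit of > 80 nM in this assay, at which 1 of the 2 values shown sits)). Compound 3 `CCCNC(=O)c1sc2nc(-c3cccs3)cc(-c3ccccc3)c2c1N` differs from compound 2 by propylcarbamoyl in place of butylsulfanyl on an aromatic carbon. For the measured compounds named here, no measured step bears on this change with a readable size, so no direction beyond the scatter can be set from the data; the propylcarbamoyl shares a carbonyl with the ethoxycarbonyl of compound 1. Compound 3 is therefore expected to fall near 3000 nM, between 300 nM and 30000 nM, an estimated step that the limit leaves unreadable from compound 2 to compound 3.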

Compound 3, half-maximal inhibitory concentration: > 7500 nM
Compound 3 gave a limit, no number; the forecaster's own chance of this, stated with the estimate: 50%; middle value at least 2.5-fold (0.39 log units) away from the limit.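

In this assay compound 3 returns only a limit, > 7500 nM. For the compounds shown here, no step among compound 1, compound 2 and compound 3 can therefore be read. The compounds shown leave open how strongly each inhibits, and whether ethoxycarbonyl, butylsulfanyl and propylcarbamoyl differ at all on this aromatic carbon.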